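This account rests on a few compounds, and the source may have more. Where it says the series, first, only, none or still open, it means among the compounds named here.

The study measures cell activity in a functional assay on cells (Lymphocyte, Homo sapiens), read by trypan blue exclusion, with a stated time of 16 h, tested at 2.5 uM; a lower number here means a weaker effect, a higher number a stronger effect of the compound at the concentration tested. Compound 1, with the structure `CCCCCCCCCCCCCCCCc1nc(N2CCC2)c(C)c(C)c1O`, gives 87% in this assay. Compound 2, with the structure `Cc1c(N(C)C)nc(CCCCCCCCCCO)c(O)c1C`, gives 87% in this assay, so on the numbers shown compound 2 stands level with compound 1, the nearest comparison, and the two values lie within the usual scatter of each other. Compound 3, with the structure `CCCCCCCCCCc1nc(N(C)C)c(C)c(C)c1O`, has not yet been measured in this assay. It differs from compound 2 in one place: hydrogen in place of hydroxy on a saturated chain carbon, ten or more bonds along the chain from an aromatic carbon. Among the measured compounds shown here, no step between two measured compounds that differ in only one place is available to set the size of this change. What the data offer is that compound 1 carries a saturated chain without a hydroxy and compound 2 carries a chain with one, and both read the same in this assay. On that footing compound 3 is expected to show little or no change beyond the scatter, with an estimated step of a number 2 percentage points lower from compound 2 to compound 3 (within the scatter). For compound 3 the expected value in this assay is 85%, with a range from 70% to 95%.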

Compound 3, a percentage reported as activity, at one concentration (the size of the read-out at that concentration, not a potency): 87%
Compound 3: the middle estimate sits 2 percentage points below what was measured; the range from low to high includes it.
By their numbers in this assay, from the lowest: compounds 1, 2 and 3 (each within the scatter of the next).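

In this assay, among the compounds shown here, replacing the hydroxy of compound 2 with hydrogen gives no change at the digits printed from compound 2 to compound 3 (within the scatter) and so provides the first step in this set in which only one place changes. At this place, on a saturated chain carbon, the read-out at the concentration tested therefore does not depend on whether the chain ends in hydroxy or hydrogen. No supporting measurement is available to explain this result.

The compounds shown leave open whether an amine or a carboxylic acid at the same place would also read level with compound 2, and whether a longer chain carrying the hydroxy would do so as well. From the compounds shown here alone, because each compound is reported at a single concentration, it also remains open whether compound 2 and compound 3 would still read alike at lower concentrations, where a full concentration-response comparison could reveal a difference that this one reading cannot show.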